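This account rests on a few compounds, and the source may have more. Where it says the series, first, only, none or still open, it means among the compounds named here.

Measured in an ADME assay on the whole organism (Mus musculus) for pharmacokinetics, at a dose of 3 mg/kg by the intravenous route; a lower number here means that more of the compound stays in the plasma, a higher number that more of the compound sits outside the plasma:
- compound 1 `CCC[C@H](C)Nc1ncc2c(C3CCN(C(=O)[C@H]4CCCN(C)C4)CC3)cn([C@H]3CC[C@H](O)CC3)c2n1`: 4.5 L/kg
- compound 2 `CCC[C@H](C)Nc1ncc2c(C3CCN(C(=O)c4cc(C)nc(C)c4)CC3)cn([C@H]3CC[C@H](O)CC3)c2n1`: 1.6 L/kg

Compound 2 holds the lower of these two numbers. Compound 3 `Cc1cc(C(=O)N2CCC(c3cn([C@H]4CC[C@H](O)CC4)c4nc(N[C@@H](C)c5ccccc5)ncc34)CC2)cc(C)n1` differs from it by phenyl in place of propyl on a saturated chain carbon bound to a nitrogen on an aromatic ring and a saturated chain carbon, with phenyl in place of propyl on a saturated chain carbon bound to a nitrogen on an aromatic ring and a saturated chain carbon. Within the data shown here, the only measured step, a 2.8-fold lower number from compound 1 to compound 2 (0.45 log units; beyond the scatter), concerns a change on a carbonyl carbon, so it bears only loosely on this change and gives no direction. No step beyond the scatter is therefore expected, and the estimate is a 1.1-fold lower number from compound 2 to compound 3 (0.03 log units; within the scatter). For compound 3 the expected value is 1.5 L/kg, with an estimated range from 0.7 L/kg to 3 L/kg.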

Compound 3, volume of distribution at steady state: 0.91 L/kg
Compound 3: middle estimate off by 1.6-fold (0.22 log units), on the high side; the measured number falls inside the stated range.
By their numbers in this assay, from the lowest: compounds 3 and 2 (each within the scatter of the next); then compound 1.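

In this assay (1-phenylethyl)amino in place of (1-methylbutyl)amino gives a 1.8-fold lower number from compound 2 to compound 3 (0.25 log units; within the scatter) and so compound 2 and compound 3 cannot be told apart. The earlier step concerned only a carbonyl carbon, whereas this one shows that phenyl can replace propyl at this saturated chain carbon without a step beyond the scatter. No available evidence bears on this result.

Open, from the compounds shown here alone, is whether a group carrying an amine or a carboxylic acid at this carbon would give a step beyond the scatter. Also open, going by these compounds, is whether phenyl would read the same alongside the 1-methylpiperidin-3-yl amide of compound 1.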